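Hydroxy in Place of Hydrogen: What to Expect for Compound 4

This account rests on a few compounds, and the source may have more. Where it says the series, first, only, none or still open, it means among the compounds named here.

Three compounds have been measured in an assay for binding affinity to dual specificity mitogen-activated protein kinase kinase 4 (Homo sapiens), read by KINOMEscan, tested at 100 nM; on this read-out higher numbers stand for a weaker effect at the one concentration tested and lower numbers for a stronger effect:
compound 1 `CCCS(=O)(=O)Nc1ccc(F)c(C(=O)c2n[nH]c3ncc(-c4ccccc4)cc23)c1F` gives 2.4%;
compound 2 `CCCS(=O)(=O)Nc1ccc(F)c(C(=O)c2n[nH]c3ncc(-c4ccc(C)cc4)cc23)c1F` gives 5.4%;
compound 3 `CCCS(=O)(=O)Nc1ccc(F)c(C(=O)c2n[nH]c3ncc(-c4cccc(O)c4)cc23)c1F` gives 2.2%.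

On these numbers compound 1 stands second highest of the three. Its nearest neighbour is compound 3, with a number 0.2 percentage points lower from compound 1 to compound 3 (within the scatter), and its furthest is compound 2, with a number 3 percentage points higher from compound 1 to compound 2 (within the scatter). Between the other two, there is a number 3.2 percentage points lower from compound 2 to compound 3 (within the scatter). All three readings are therefore low and indistinguishable within the usual scatter.

Compound 4 `CCCS(=O)(=O)Nc1ccc(F)c(C(=O)c2n[nH]c3ncc(-c4ccc(O)cc4)cc23)c1F` differs from compound 1 in one place: hydroxy in place of hydrogen on an aromatic carbon. The closest measured comparison is the step from compound 1 to compound 3, where a hydroxy also replaced a hydrogen on the same phenyl ring, and that step stayed within the scatter. The step from compound 1 to compound 2, a methyl in place of hydrogen on that ring, also stayed within the scatter. No measured change on this ring has moved the reading beyond the scatter, so for compound 4 no step beyond the scatter is expected: a number 0.6 percentage points higher from compound 1 to compound 4 (within the scatter). Compound 4 is accordingly estimated at 3%, with a range from 0.5% to 10%.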

Compound 4, a percentage reported as activity, at one concentration (the size of the read-out at that concentration, not a potency): 0.75%
Compound 4: middle estimate off by 2.3 percentage points, on the high side; measured number inside the range.
By their numbers in this assay, from the lowest: compounds 4, 3, 1 and 2 (each within the scatter of the next).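

In this assay putting a hydroxy on the phenyl ring, para to a large group, gives a number 1.7 percentage points lower from compound 1 to compound 4 (within the scatter) and so leaves the reading not distinguishable from that of the unsubstituted phenyl. Among these compounds, the new compound also adds two comparisons that the earlier compounds could not give: going from 3-hydroxyphenyl to 4-hydroxyphenyl gives a number 1.5 percentage points lower from compound 3 to compound 4 (within the scatter) and exchanging methyl for hydroxy at this place gives a number 4.7 percentage points lower from compound 2 to compound 4 (within the scatter) so neither where the hydroxy sits, of these two places, nor which of these two groups is present separates the readings. Nothing measured alongside these compounds bears on what lies behind these close readings.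

On these data alone, all the readings so far are low and close together, so it stays open whether a carboxylic acid, an amine or a longer chain such as butoxy at this place would move the reading in this assay beyond the scatter. The rest of the molecule is the same in all four compounds, so they say nothing about how a change anywhere else would read.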